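Swapping cyclopentyl for pyrrolidin-1-yl on a carbonyl carbon

The compounds below may be only part of what the source reports. "The series", "measured", "known", "first", "only" and "open" are said of these compounds alone.

In a physicochemical assay for solubility, read by HPLC, in phosphate buffer, measured as kinetic solubility, at pH 7.4 (on this read-out higher numbers stand for higher solubility and lower numbers for lower solubility), compound 1 `CC(C)(C)C(=O)c1cc(-c2ccc(S(N)(=O)=O)cc2)n(-c2ccc(Cl)cc2)n1` gives 6600 nM and compound 2 `NS(=O)(=O)c1ccc(-c2cc(C(=O)C3CCCC3)nn2-c2ccc(Cl)cc2)cc1` gives 4600 nM, so these two stand within the scatter of each other. Compound 3 `NS(=O)(=O)c1ccc(-c2cc(C(=O)N3CCCC3)nn2-c2ccc(Cl)cc2)cc1` carries pyrrolidin-1-yl in place of cyclopentyl on a carbonyl carbon. Going by the values given here, no measured step makes this exact change. Among the compounds with values here, the only measured step, a 1.4-fold lower number from compound 1 to compound 2 (0.16 log units; within the scatter), swaps one group for another on that same carbonyl carbon, so no step beyond the scatter is expected in this assay. The expected step is a 1.1-fold higher number from compound 2 to compound 3 (0.04 log units; within the scatter). For compound 3 the estimate is 5000 nM, with an expected range of 2200 nM to 11000 nM.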

Compound 3, solubility: 57900 nM
Compound 3: middle estimate off by 12-fold (1.06 log units), on the low side; measured number above the stated range.
By their numbers in this assay, from the lowest: compounds 2 and 1 (each within the scatter of the next); then compound 3.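

At this carbonyl carbon, swapping one carbon group for another had stayed within the scatter, yet pyrrolidin-1-yl gives a 13-fold higher number from compound 2 to compound 3 (1.10 log units; beyond the scatter) in this assay, and also an 8.8-fold higher number from compound 1 to compound 3 (0.94 log units; beyond the scatter). Between cyclopentyl and pyrrolidin-1-yl, the number of heavy atoms stays the same and a single ring carbon becomes nitrogen, so a small structural edit can go with a large change in this read-out. Nothing available explains this rise. Going by these compounds, whether it belongs to pyrrolidin-1-yl alone or extends to other groups attached through nitrogen, such as piperidin-1-yl, morpholin-4-yl or dimethylamino, remains open.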